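This account rests on a few compounds, and the source may have more. Where it says the series, first, only, none or still open, it means among the compounds named here.

Measured so far:
Compound 1 `O=C(c1ccc(Cl)cc1)n1c(-c2ccccc2[N+](=O)[O-])nc2ccccc21`: 3.6
Compound 2 `O=C(c1ccc([N+](=O)[O-])cc1)n1c(-c2ccccc2[N+](=O)[O-])nc2ccccc21`: 2.8

In a physicochemical assay for lipophilicity (on this read-out lower numbers stand for lower lipophilicity and higher numbers for higher lipophilicity), compound 1 gives the highest of these two numbers, with compound 2 next at a number 0.80 log units lower from compound 1 to compound 2 (beyond the scatter). Compound 3 `O=[N+]([O-])c1ccccc1-c1nc2ccccc2[nH]1` differs from compound 1 by hydrogen in place of (4-chlorophenyl)carbonyl on an aromatic nitrogen. Among the measured compounds shown here, no measured step covers this exact change; the only step seen, nitro in place of chloro, was modest. Removing a whole (4-chlorophenyl)carbonyl with its chlorine is a larger change, so a drop in this assay of a number 0.70 log units lower from compound 1 to compound 3 (beyond the scatter) is expected, beyond the scatter. Compound 3 is estimated at 2.9, with a range of 2.3 to 3.5.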

Compound 3, partition coefficient: 2.2
For compound 3 the middle estimate is 0.70 log units above the measured one, outside the stated range (below it).
By their numbers in this assay, from the lowest: compound 3; then compound 2; then compound 1.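

In this assay, replacing the whole (4-chlorophenyl)carbonyl on the aromatic nitrogen with hydrogen gives a number 1.40 log units lower from compound 1 to compound 3 (beyond the scatter) and counts as a large step. Changing this group on the nitrogen therefore moves the number further than the earlier swap on its ring, which gave a number 0.80 log units lower from compound 1 to compound 2 (beyond the scatter) and counted as modest. Nothing available explains the size of this step.

The compounds shown leave open how much of the step belongs to the chlorine, the aromatic ring or the carbonyl. A methyl or an acetyl on this nitrogen could help separate those parts.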